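Methylsulfanyl in Place of Hydroxy: An Expected Limit

The compounds below may be only part of what the source reports. "The series", "measured", "known", "first", "only" and "open" are said of these compounds alone.

Compound 1 `CSc1nnc(-c2ccccc2)c2c(C)nc(C(C)C)n12` — a functional assay for inhibition, with Homo sapiens as the target; a lower number here means a stronger inhibitor, a higher number a weaker inhibitor: > 48000 nM
Compound 2 `CCc1nc(C)c2c(-c3ccccc3)nnc(O)n12` — this assay: > 48000 nM

In this assay compound 1 reaches only the limit of the assay, > 48000 nM. Compound 2 likewise gives only a limit, > 48000 nM. Compound 2 thus stands at the limit of > 48000 nM in this assay, at which 2 of the 2 values shown sit, where every value shown sits.

Compound 3 `CCc1nc(C)c2c(-c3ccccc3)nnc(SC)n12` differs from compound 2 by methylsulfanyl in place of hydroxy on an aromatic carbon. For the measured compounds named here, no step between measured compounds is available. Compound 1 also carries methylsulfanyl and gives a limit, > 48000 nM. Compound 3 is therefore expected to remain at the limit, with a step that the limit leaves unreadable from compound 2 to compound 3 of no size beyond the scatter in this assay. Compound 3 is estimated at 60000 nM, between 20000 nM and 200000 nM.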

Compound 3, half-maximal inhibitory concentration: > 48000 nM
Compound 3 was reported as a limit (the forecaster's own chance of this, stated with the estimate: 80%); the middle value is on the limit's open side.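

No step from compound 1 or compound 2 to compound 3 can be read in this assay, since all three values are limits: the limit of > 48000 nM in this assay, at which 3 of the 3 values shown sit.

The compounds shown leave open how strongly any of them inhibits, and whether methylsulfanyl in place of hydroxy changes that at all.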